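This account rests on a few compounds, and the source may have more. Where it says the series, first, only, none or still open, it means among the compounds named here.

Three compounds have been measured:

compound 1, `COc1ccc([C@@H]2C/C(=N/OCc3cn(-c4ccc(Cl)cc4C)nn3)c3cc(CC=C(C)C)c(OC)cc3O2)cc1`, with 49% in a functional assay on PC-3 cells (Homo sapiens) for inhibition, read by sulforhodamine B assay, with a stated time of 48 h, tested at 50 uM; on this read-out lower numbers stand for less inhibition of growth and higher numbers for more inhibition of growth at the one concentration tested
compound 2, `CCOc1ccc([C@@H]2CC(=O)c3cc(CC=C(C)C)c(OC)cc3O2)cc1`, with 60%
compound 3, `COc1ccc([C@@H]2C/C(=N/OCc3cn(-c4ccc(C(=O)c5ccccc5)cc4)nn3)c3cc(CC=C(C)C)c(OC)cc3O2)cc1`, with 40%

Among these three numbers compound 2 stands highest. Its nearest neighbour is compound 1, whose value lies lower by a gap that goes beyond the usual scatter of this kind of measurement, and compound 3 lies further below, also beyond the scatter. Compound 2 is therefore the most active of the three in this assay on the numbers shown.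

The next compound, compound 4, `COc1ccc([C@@H]2CC(=O)c3cc(CC=C(C)C)c(OC)cc3O2)cc1`, has not yet been measured. It is derived from compound 2 by a single small change: hydrogen in place of methyl on a saturated chain carbon bound to an oxygen on an aromatic ring. Put another way, an ethoxy group becomes a methoxy group, so a 4-ethoxyphenyl ring becomes a 4-methoxyphenyl ring; the rest of the molecule is untouched.

Within the data shown here, no measured pair in this set differs by this change alone, so nothing here shows directly what it does. Given how small the alteration is, the expected step in this assay from compound 2 to compound 4 is a number 5 percentage points lower from compound 2 to compound 4 (within the scatter), a change not expected to reach beyond the scatter in either direction. On that basis compound 4 is estimated to give about 55%, with a plausible range from 35% to 75%.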

Compound 4, percent growth inhibition at one concentration: 58%
The estimate for compound 4 lay 3 percentage points below the measured number; measured number inside the range.
By their numbers in this assay, from the lowest: compounds 3, 1, 4 and 2 (each within the scatter of the next, the first and the last beyond it).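

In this assay, among these compounds, replacing the 4-ethoxyphenyl ring with a 4-methoxyphenyl ring gives a number 2 percentage points lower from compound 2 to compound 4 (within the scatter) and is the first direct test of a single change in this set, since the earlier compounds differ from one another in more than one place. At this position, on a saturated chain carbon bound to an oxygen on an aromatic ring, hydrogen can therefore take the place of methyl without a difference that this read-out can separate from ordinary repeat variation, so ethoxy and methoxy cannot be told apart here. The result describes only what happens to the number, and nothing available explains why the two compounds read alike.

Among the compounds shown here, the pair covers only two groups at this site, so it leaves open whether a longer chain such as butoxy, or a hydroxyl group or an amine in place of the ethoxy, would keep the same level of growth inhibition. With a single test concentration and a single cell line, it also leaves open whether compound 2 and compound 4 would still read alike across a range of concentrations or in other cells.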